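Thiol in place of bromomethyl ketone on the shared core

A few compounds are considered here, and "the series" means these few. Any claim that something is new, unique, unknown or untested is made for them only; others in the source may bear on it.

Compound 3 `O=C(CBr)c1cc(C(F)(F)F)cc(C(F)(F)F)c1` sits at the floor of an ADME assay for pharmacokinetics, read by LC-MS, in phosphate buffer, with a stated time of 72 h, at pH 7.4, tested at 250 uM; on this read-out higher numbers stand for a longer-lived compound and lower numbers for a shorter-lived compound: in this assay compound 3 gives < 0.017 h, a limit and not a number. Compound 1 `C=CC(=O)Oc1cc(C(F)(F)F)cc(C(F)(F)F)c1` in this assay gives < 0.017 h, also a limit. Both sit at the limit of < 0.017 h in this assay, at which 2 of the 3 values shown sit. Compound 2 `C#Cc1cc(C(F)(F)F)cc(C(F)(F)F)c1` gives 0.3 h in this assay. Compound 4 `FC(F)(F)c1cc(S)cc(C(F)(F)F)c1` differs from compound 3 by sulfanyl in place of (bromomethyl)carbonyl on an aromatic carbon. Going by the values given here, the steps of an at least 17-fold higher number from compound 1 to compound 2 (1.24 log units; beyond the scatter) and an at least 17-fold lower number from compound 2 to compound 3 (1.24 log units; beyond the scatter) are large moves between the limit and the one read number, while the step that the two limits leave unreadable from compound 1 to compound 3 stays between two limits. Loss of the (bromomethyl)carbonyl is expected to lengthen the half-life, an at least 230-fold higher number from compound 3 to compound 4 (2.37 log units; beyond the scatter), into the readable range. Compound 4 is therefore estimated at 4 h in this assay, within 0.3 h to 50 h.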

Compound 4, half-life: 11.2 h
For compound 4 the middle estimate is 2.8-fold (0.45 log units) below the measured one, within the range that was stated.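

In this assay, sulfanyl on this aromatic carbon gives the first half-life well clear of the ethynyl value, with a 37-fold higher number from compound 2 to compound 4 (1.57 log units; beyond the scatter). Against the two compounds held at a limit, the same position shows an at least 650-fold higher number from compound 3 to compound 4 (2.81 log units; beyond the scatter) and an at least 650-fold higher number from compound 1 to compound 4 (2.81 log units; beyond the scatter), both minimum sizes only. Compound 1 and compound 3 remain limits and not numbers: the limit of < 0.017 h in this assay, at which 2 of the 4 values shown sit.

Going by these compounds, whether an amine or a hydroxyl group on the same aromatic carbon would give a half-life of this order stays open. On these data alone, whether the sulfanyl hydrogen itself matters, as against a methylthio group, also stays open.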